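Replacing 2,5-dimethylphenyl with 4-chlorophenyl on the shared core

A few compounds are considered here, and "the series" means these few. Any claim that something is new, unique, unknown or untested is made for them only; others in the source may bear on it.

Compound 1 `Cc1ccc(C)c(-c2nc(CN3CCC(C(=O)NCCCN4C[C@H](C)C[C@H](C)C4)CC3)c(C)o2)c1` offers no starting number: in a physicochemical assay for permeability, using PAMPA (on this read-out lower numbers stand for lower permeability and higher numbers for higher permeability), compound 1 is recorded as "not determined" (no result reported). Compound 4 `Cc1oc(-c2ccc(Cl)cc2)nc1CN1CCC(C(=O)NCCCN2C[C@H](C)C[C@H](C)C2)CC1` differs from it in one place: 4-chlorophenyl in place of 2,5-dimethylphenyl on an aromatic carbon. The exchange, 4-chlorophenyl in place of 2,5-dimethylphenyl, sits on an aromatic carbon of a five-membered aromatic ring with 1 nitrogen and 1 oxygen.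

Going by the values given here, only two related structures have numbers. Compound 2 `CC[C@@H]1C[C@H](CC)CN(CCCNC(=O)C2CCN(Cc3nc(-c4ccccc4C)oc3C)CC2)C1` gives 1270 10^-6 cm/s, and compound 3 `Cc1ccccc1-c1nc(CN2CCC(C(=O)NCCCN3CCC(C)(C)CC3)CC2)c(C)o1` gives 241 10^-6 cm/s. Among the compounds with values here, the single measured step, a 5.3-fold lower number from compound 2 to compound 3 (0.72 log units; beyond the scatter), is modest but beyond the scatter. It exchanges 3,5-diethylpiperidin-1-yl for 4,4-dimethylpiperidin-1-yl and leaves the aromatic group unchanged, so it says nothing direct about the exchange at hand. Within the data shown here, with no number for compound 1 and no measured step of this kind, neither a size nor a direction can be assigned to the change in this assay. The estimate therefore leans on compound 3 at 241 10^-6 cm/s, and the range is kept wide. Compound 4 is expected near 300 10^-6 cm/s, with an estimated range of 90 10^-6 cm/s to 1000 10^-6 cm/s.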

Compound 4, apparent permeability: > 635 10^-6 cm/s
Compound 4 was reported as a limit (the forecaster's own chance of this, stated with the estimate: 5%); middle value at least 2.1-fold (0.32 log units) from the limit.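

Going by these compounds alone, compound 4 is reported only as a limit and compound 1 has no reported result, so no step between compound 1 and compound 4 can be read in this assay: the limit of > 635 10^-6 cm/s in this assay, at which 1 of the 4 values shown sits. The compounds shown leave open how far, and in which direction, 4-chlorophenyl in place of 2,5-dimethylphenyl moves this read-out.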